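Working notes on the amide series: the step to compound 4

The source may report more compounds than this note shows. Statements on the series, on what has been measured and on what is new or still open speak of the compounds shown alone.

Compound 1 `CS(=O)(=O)N1CCN(CC(O)CN2CCC(CNC(=O)c3cccc4[nH]cnc34)CC2)CC1`: 10 nM
Compound 2 `CCc1nc2c(C(=O)NCC3CCN(CC(O)CN4CCN(S(C)(=O)=O)CC4)CC3)cccc2[nH]1`: 1 nM
Compound 3 `CC(=O)N1CCN(CCN2CCC(CNC(=O)c3cccc4[nH]c(C(C)C)nc34)CC2)CC1`: 3.16 nM

In a functional assay for agonist activity at 5-hydroxytryptamine receptor 4 (Homo sapiens), read by cAMP accumulation (on this read-out lower numbers stand for an effect already at smaller amounts and higher numbers for an effect only at larger amounts of compound), compound 3 gives 3.16 nM, the second highest of the three numbers; compound 2 lies lower and compound 1 higher, each beyond the scatter. Within the data shown here, the only single-place step measured, a 10-fold lower number from compound 1 to compound 2 (1.00 log units; beyond the scatter), concerns a substituent on an aromatic carbon of the shared core and does not touch the chain altered here. Compound 4 `CC(=O)N1CCC(CN2CCC(CNC(=O)c3cccc4[nH]c(C(C)C)nc34)CC2)CC1` differs from compound 3 by 1-acetylpiperidin-4-yl in place of (4-acetylpiperazin-1-yl)methyl on a saturated chain carbon bound to an amine nitrogen in a ring. Among the measured compounds shown here, no measured pair bears on this change, so no step beyond the scatter in this assay is expected in either direction, and the range is kept wide. Compound 4 is therefore estimated at 4 nM, between 1 nM and 20 nM. The expected step is a 1.3-fold higher number from compound 3 to compound 4 (0.10 log units; within the scatter).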

Compound 4, half-maximal effective concentration: 1.59 nM
Estimate against measurement, compound 4: 2.5-fold (0.40 log units) above, and the stated range covers the measured number.
By their numbers in this assay, from the lowest: compounds 2, 4 and 3 (each within the scatter of the next, the first and the last beyond it); then compound 1.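

In this assay, among these compounds, the first single-place step on this chain reads a 2.0-fold lower number from compound 3 to compound 4 (0.30 log units; within the scatter), so the exchange of a ring with 2 hetero atoms for one with 1 hetero atom, with the acetyl group kept, does not separate the two compounds. This place on the chain therefore accepts either group without a step beyond the scatter. No measurement at hand explains this result.

Still open, going by these compounds, is how a carboxylic acid or a free amine in place of the acetyl group would read. Also open, on these data alone, is whether the same exchange would read alike with ethyl on the aromatic carbon of the shared core.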